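The compounds below may be only part of what the source reports. "The series", "measured", "known", "first", "only" and "open" are said of these compounds alone.

Working notes on the series.

Among the compounds with values here, compound 3, `Cc1cc(OCCCCCCC[N+]2(C)CCCC2)cc(-n2cc(C(=O)Nc3cc(F)cc(F)c3)c(=O)c3ccc(N(C)C)nc32)c1`, stands at the top of the three numbers so far in an assay on LX2 cells for inhibition of COL1A1 promoter (Homo sapiens), read by a luciferase reporter, with a stated time of 24 h, tested at 50 uM (a lower number here means a weaker effect, a higher number a stronger effect of the compound at the concentration tested), where compound 3 gives 35.4%. Compound 2, `CN(C)c1ccc2c(=O)c(C(=O)Nc3cc(F)cc(F)c3)cn(-c3ccc(Cl)c(OCCCCCCC[N+]45CCN(CC4)CC5)c3)c2n1`, comes nearest; in this assay compound 2 gives 18.7%, and the gap to compound 3 is beyond the scatter. Compound 1, `Cc1ccc(-n2cc(C(=O)Nc3cc(F)cc(F)c3)c(=O)c3ccc(N(C)C)nc32)cc1OCCCCCCC[N+]12CCN(CC1)CC2`, lies furthest off; in this assay compound 1 gives 9.71%, again beyond the scatter from compound 3. Within the data shown here, the only single-point step measured so far runs a number 9 percentage points higher from compound 1 to compound 2 (within the scatter), and it does not touch the charged end of the chain.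

Compound 4, `CC[N+]1(CCCCCCCOc2cc(C)cc(-n3cc(C(=O)Nc4cc(F)cc(F)c4)c(=O)c4ccc(N(C)C)nc43)c2)CCCCC1`, is reached from compound 3 by one change: a group of 8 heavy atoms (7 carbon, 1 nitrogen; one six-membered non-aromatic ring with 1 hetero atom) in place of a group of 6 heavy atoms (5 carbon, 1 nitrogen; one five-membered non-aromatic ring with 1 hetero atom), on a saturated chain carbon, seven bonds along the chain from an oxygen on an aromatic ring

Among the measured compounds shown here, no measured step alters this part of the molecule, so nothing bears directly on the move. Compound 1 and compound 2 carry a different charged group from compound 3 but also differ elsewhere, so their values only show that the charged end can sit with lower or higher numbers without a single-point comparison. The expectation is therefore for no step beyond the scatter, with a number 2.6 percentage points higher from compound 3 to compound 4 (within the scatter) as the estimated step. Compound 4 is expected to give 38% in this assay, estimated between 20% and 56%.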

Compound 4, a percentage reported as inhibition, at one concentration (the size of the read-out at that concentration, not a potency): 86.6%
Compound 4: middle estimate off by 48.6 percentage points, on the low side, outside the stated range (above it).
By their numbers in this assay, from the lowest: compounds 1 and 2 (each within the scatter of the next); then compound 3; then compound 4.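

In this assay, within the data shown here, the charged end of the chain turns out to matter strongly, with a number 51.2 percentage points higher from compound 3 to compound 4 (beyond the scatter) as the first measured step at this place, on a saturated chain carbon, seven bonds along the chain from an oxygen on an aromatic ring. Both groups carry net charge +1 and count 0 hydrogen-bond donors and 0 hydrogen-bond acceptors, so the step arises with those counts unchanged, while the ring goes from five-membered to six-membered and the group from 6 heavy atoms to 8. Nothing measured here accounts for the size of this step.

Among these compounds, the single change bundles the ring size with the carbon group on the charged nitrogen, so a piperidinium ring carrying a methyl on its nitrogen, or a pyrrolidinium ring carrying an ethyl there, would be needed to tell which part goes with the higher number. Also open, as far as these compounds go, is how far the trend runs at this end of the chain, for instance with a seven-membered azepanium ring or a propyl on the charged nitrogen.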